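A tert-butyl group on an amine nitrogen

This account rests on a few compounds, and the source may have more. Where it says the series, first, only, none or still open, it means among the compounds named here.

In a functional assay on L1210 cells (Mus musculus) for inhibition (a lower number here means a stronger inhibitor, a higher number a weaker inhibitor), compound 2 `CCNCCCCNCCCCNCCCCN` gives 1100 nM. This lies within the scatter of compound 1 `CCNCCCNCCCCNCCCN` at 1700 nM. Compound 3 `CC(C)NCCCCNCCCCNCCCCNC(C)C` reads 8100 nM, clearly beyond the scatter from compound 2 and towards weaker inhibition. Compound 4 `CCNCCCCNCCCCNCCCCNC(C)(C)C` departs from compound 2 by tert-butyl in place of hydrogen on an amine nitrogen, with tert-butyl in place of hydrogen on an amine nitrogen. Going by the values given here, no measured step shows this change directly. Among the compounds with values here, the expectation therefore leans on compound 3 at 8100 nM, the only measured compound with a branched group on an amine nitrogen. The expected 2.7-fold higher number from compound 2 to compound 4 (0.44 log units; beyond the scatter) is towards a higher number and modestly beyond the scatter. Compound 4 is expected at 3000 nM, with an estimated range of 900 nM to 10000 nM.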

Compound 4, inhibition constant: 3000 nM
For compound 4 middle estimate and measured number coincide at the digits printed; low and high end bracket the measured number.
By their numbers in this assay, from the lowest: compounds 2, 1 and 4 (each within the scatter of the next, the first and the last beyond it); then compound 3.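

In this assay, tert-butyl in place of hydrogen on an amine nitrogen gives the first step read at a single place in this series, a 2.7-fold higher number from compound 2 to compound 4 (0.44 log units; beyond the scatter), a modest move towards weaker inhibition. Inhibition therefore persists with this group on a nitrogen whose other neighbours are saturated chain carbon, at a cost beyond the scatter. Nothing available explains the size of this step. On these data alone, how a methyl group, a longer chain or a carboxylic acid at this place would compare with tert-butyl remains open.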